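A few compounds are considered here, and "the series" means these few. Any claim that something is new, unique, unknown or untested is made for them only; others in the source may bear on it.

Three analogues of one core have been measured in an assay on membranes from brain for displacement of a labelled ligand from Neuronal acetylcholine receptor; alpha4/beta2 (Rattus norvegicus), with a stated time of 3 h; on this read-out lower numbers stand for stronger inhibition and higher numbers for weaker inhibition. Compound 1 `CC(=O)c1ccc(/C=C2\CCCN=C2c2cccnc2)cc1` gives 4490 nM; compound 2 `N#Cc1ccc(/C=C2\CCCN=C2c2cccnc2)cc1` gives 1230 nM; compound 3 `CC(C)(C)C(=O)Oc1ccc(/C=C2\CCCN=C2c2cccnc2)cc1` gives 830 nM. Among the measured compounds shown here, compound 3 has the lowest number of the three, but the gap to compound 2 is within the scatter, so only the step from compound 1 is clear: a 5.4-fold lower number from compound 1 to compound 3 (0.73 log units; beyond the scatter), alongside a 3.7-fold lower number from compound 1 to compound 2 (0.56 log units; beyond the scatter) and a 1.5-fold lower number from compound 2 to compound 3 (0.17 log units; within the scatter).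

Compound 4 `Clc1ccc(/C=C2\CCCN=C2c2cccnc2)cc1` differs from compound 3 as follows: chloro in place of ((tert-butyl)carbonyl)oxy on an aromatic carbon. For the measured compounds named here, no measured step exchanges either of these two groups, so the three steps only show that the group at this position moves the number by a modest amount and that the two non-acetyl groups sit close together. The expectation for compound 4 in this assay is therefore a number near compound 3, with a wide range and no direction firmly beyond the scatter: a 1.8-fold higher number from compound 3 to compound 4 (0.26 log units; within the scatter). Compound 4 is estimated at 1500 nM, between 400 nM and 6000 nM.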

Compound 4, inhibition constant: 970 nM
Beside the measured number, compound 4's estimate is 1.5-fold (0.19 log units) above it; low and high end bracket the measured number.
By their numbers in this assay, from the lowest: compounds 3, 4 and 2 (each within the scatter of the next); then compound 1.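

Chloro in place of ((tert-butyl)carbonyl)oxy gives a 1.2-fold higher number from compound 3 to compound 4 (0.07 log units; within the scatter), so at this position the number does not separate a single chlorine atom from a group of seven heavy atoms that carries hydrogen-bond acceptors. Chloro in place of cyano gives a 1.3-fold lower number from compound 2 to compound 4 (0.10 log units; within the scatter), while chloro in place of acetyl gives a 4.6-fold lower number from compound 1 to compound 4 (0.67 log units; beyond the scatter), which leaves acetyl as the only one of the four groups set apart, now against three different replacements. No measurement available here accounts for this grouping.

From the compounds shown here alone, whether an amine or a carboxylic acid on this aromatic carbon would fall with chloro, cyano and ((tert-butyl)carbonyl)oxy or nearer acetyl remains open. Also open, going by these compounds, is whether a ketone with a longer chain would keep the number of acetyl.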